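One aryl swap, tried on a second core

A few compounds are considered here, and "the series" means these few. Any claim that something is new, unique, unknown or untested is made for them only; others in the source may bear on it.

Measured so far in an ADME assay on RAW264.7 cells (Mus musculus) for cytotoxicity, with a stated time of 24 h; a higher number here means a weaker inhibitor, a lower number a stronger inhibitor:
Compound 1 `COc1ccc(-c2cc(-c3ccc4c(c3)CCCC4)nc(NCc3ccccc3)c2C#N)cc1OC` gives 4900 nM.
Compound 2 `CC(C)c1ccc(-c2cc(-c3ccc4c(c3)CCCC4)nc(NCc3ccccc3)c2C#N)cc1` gives > 50000 nM, which is a limit of the assay rather than a number.
Compound 3 `CCOC(=O)COc1nc(-c2ccc3c(c2)CCCC3)cc(-c2ccc(OC)c(OC)c2)c1C#N` gives 26200 nM.

Between compound 1 and compound 2 the change is 4-isopropylphenyl in place of 3,4-dimethoxyphenyl on an aromatic carbon, and it gave an at least 10-fold higher number from compound 1 to compound 2 (1.00 log units; beyond the scatter), the step running into (the limit of > 50000 nM in this assay, at which 1 of the 3 values shown sits). Compound 3 rests on a different core, which differs from compound 1 by (ethoxycarbonyl)methoxy in place of benzylamino on an aromatic carbon, with a 5.3-fold higher number from compound 1 to compound 3 (0.73 log units; beyond the scatter). Compound 4 `CCOC(=O)COc1nc(-c2ccc3c(c2)CCCC3)cc(-c2ccc(C(C)C)cc2)c1C#N` applies the same kind of change to compound 3: 4-isopropylphenyl in place of 3,4-dimethoxyphenyl on an aromatic carbon. The surroundings are not identical: in compound 1 the place is meta to a benzylamino group, whereas in compound 3 it is meta to a (ethoxycarbonyl)methoxy group. For compound 4 the expected step is a 4.6-fold higher number from compound 3 to compound 4 (0.66 log units; beyond the scatter), because the same kind of change gave an at least 10-fold higher number from compound 1 to compound 2 (1.00 log units; beyond the scatter). Compound 4 is therefore expected at 120000 nM, quite possibly reported only as a limit.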

Compound 4, half-maximal inhibitory concentration: > 50000 nM
Compound 4 gave a limit, no number (the forecaster's own chance of this, stated with the estimate: 75%); the middle value does not contradict the limit.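

Compound 4 gives > 50000 nM in this assay, a limit and not a number, and the swap to 4-isopropylphenyl on this core yields only a floor, an at least 1.9-fold higher number from compound 3 to compound 4 (0.28 log units; that floor lies within the scatter). Set beside the first core, the result shows no reversal of direction, but it establishes neither a matching size nor a real difference between the cores: the same change on two cores in this assay, an at least 10-fold higher number (1.00 log units; beyond the scatter) from compound 1 to compound 2 and an at least 1.9-fold higher number (0.28 log units; that floor lies within the scatter) from compound 3 to compound 4; the limit leaves it open whether they differ Both compound 2 and compound 4 stand at limits, and the step from compound 2 to compound 4 cannot be read.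

Going by these compounds, the actual values of compound 2 and compound 4 in this assay remain open. So does whether a carboxylic acid or an amine in place of the isopropyl group would behave alike on both cores.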